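This account rests on a few compounds, and the source may have more. Where it says the series, first, only, none or still open, it means among the compounds named here.

Measured compounds:
Compound 1 `CCCCCCOc1ccc(C(O)C2OC(=O)c3c(OC)cc(OC)cc32)cc1` gives 5360 nM in a functional assay on RAW264.7 cells (Mus musculus) for inhibition, read by Griess assay, with stated times of 1 h and 24 h; a lower number here means a stronger inhibitor, a higher number a weaker inhibitor.
Compound 2 `COCCCOc1ccc(C(O)C2OC(=O)c3c(OC)cc(OC)cc32)cc1` gives 1260 nM in this assay.
Compound 3 `COc1cc(OC)c2c(c1)C(C(O)c1ccc(OCc3ccc(C#N)cc3)cc1)OC2=O` gives 7360 nM in this assay.

Among these three numbers in this assay, compound 1 stands second highest: compound 3 is nearest, with a 1.4-fold higher number from compound 1 to compound 3 (0.14 log units; within the scatter), and compound 2 furthest, with a 4.3-fold lower number from compound 1 to compound 2 (0.63 log units; beyond the scatter). The compound now under consideration is compound 4 `COc1cc(OC)c2c(c1)C(C(O)c1ccc(OCc3ccc(OC(F)F)cc3)cc1)OC2=O`. It differs from compound 1 in a single place: 4-(difluoromethoxy)phenyl in place of pentyl on a saturated chain carbon bound to an oxygen on an aromatic ring. Within the data shown here, the measured step that bears most directly on this change is the one from compound 1 to compound 3, where pentyl likewise gave way to an aromatic ring, there 4-cyanophenyl, and the outcome was a 1.4-fold higher number from compound 1 to compound 3 (0.14 log units; within the scatter), within the scatter. The step of a 5.8-fold higher number from compound 2 to compound 3 (0.77 log units; beyond the scatter) also puts an aromatic ring in place of a chain, but it starts from compound 2, which itself stands apart from compound 1 by a 4.3-fold lower number from compound 1 to compound 2 (0.63 log units; beyond the scatter), so it is a less direct guide. On this basis, for compound 4 a step of about a 1.2-fold higher number from compound 1 to compound 4 (0.08 log units; within the scatter) is expected, which amounts to no change beyond the scatter, leaning toward a slightly higher number if anything. Compound 4 is therefore estimated at 6500 nM, with a range from 2500 nM to 16000 nM.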

Compound 4, half-maximal inhibitory concentration: 5030 nM
For compound 4 the middle estimate is 1.3-fold (0.11 log units) above the measured one; the range from low to high includes it.
By their numbers in this assay, from the lowest: compound 2; then compounds 4, 1 and 3 (each within the scatter of the next).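

In this assay, the step of a 1.5-fold lower number from compound 3 to compound 4 (0.17 log units; within the scatter) shows that the second aromatic ring tolerates a change of its substituent, with difluoromethoxy in place of cyano on an aromatic carbon leaving the number within the scatter. Together with the step of a 1.1-fold lower number from compound 1 to compound 4 (0.03 log units; within the scatter), this gives a second aromatic replacement for pentyl that stays level with the chain, so compounds 1, 3 and 4 now form one group in which neither a plain chain nor either substituted ring sets one compound apart. Among these compounds, the step of a 4.0-fold higher number from compound 2 to compound 4 (0.60 log units; beyond the scatter) shows that compound 2 also stands apart from this new ring, making the 2-methoxyethyl replacement the only change at this place, among the four compounds, that moves the number beyond the scatter; nothing given here explains these results.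

Going by these compounds, what remains open is whether the lower number of compound 2 belongs to the chain oxygen or to the chain length, which a longer chain ending in methoxy or a chain ending in a hydroxyl group would help to separate. On these data alone, it is equally open whether an amine or a carboxylic acid on the second aromatic ring would leave the number level with that of compound 4.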